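This account rests on a few compounds, and the source may have more. Where it says the series, first, only, none or still open, it means among the compounds named here.

In an ADME assay on J774.A1 cells (Mus musculus) for cytotoxicity, read by MTT assay, with a stated time of 48 h (on this read-out higher numbers stand for lower toxicity in this test and lower numbers for higher toxicity in this test), compound 1 `COc1ccc(/C=C(\C)C(=O)/C=C/c2ccccc2)cc1` gives 54000 nM and compound 2 `COc1ccc(/C=C(\C)C(=O)/C=C/c2ccc(N(C)C)cc2)cc1` gives 36200 nM, so compound 2 stands within the scatter of compound 1. Compound 3 `C/C(=C\c1ccc(N(C)C)cc1)C(=O)/C=C/c1ccc(N(C)C)cc1` differs from compound 2 by dimethylamino in place of methoxy on an aromatic carbon. Going by the values given here, the only measured step that bears on this is a 1.5-fold lower number from compound 1 to compound 2 (0.17 log units; within the scatter), where dimethylamino replaced hydrogen, and it stayed within the scatter. No change beyond the scatter is therefore expected in this assay, and the expected step is a 1.1-fold lower number from compound 2 to compound 3 (0.05 log units; within the scatter). Compound 3 is estimated at 32000 nM, with an expected range of 14000 nM to 70000 nM.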

Compound 3, half-maximal cytotoxic concentration: 10000 nM
Compound 3: middle estimate off by 3.2-fold (0.51 log units), on the high side; measured number below the stated range.
By their numbers in this assay, from the lowest: compound 3; then compounds 2 and 1 (each within the scatter of the next).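

In this assay, dimethylamino in place of methoxy on this aromatic carbon, para to a large group, gives a 3.6-fold lower number from compound 2 to compound 3 (0.56 log units; beyond the scatter) and so passes the scatter, whereas a 1.5-fold lower number from compound 1 to compound 2 (0.17 log units; within the scatter) did not. This shows that the position can register a substituent change in this test, with compound 3 the lowest of the three. Nothing available gives a reason for this step. The compounds shown leave open whether hydrogen, a primary amine or a carboxylic acid at this position would shift the number as far, and whether the step depends on the dimethylamino group that compound 2 already carries.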